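Configuration and Cytotoxicity Across Three Measured Compounds

A few compounds are considered here, and "the series" means these few. Any claim that something is new, unique, unknown or untested is made for them only; others in the source may bear on it.

Compound 1 `C(C[C@@H]1COCCO1)C[C@@H]1COCCO1` in an ADME assay on BHK cells (Mesocricetus auratus) for cytotoxicity, read by XTT assay (on this read-out higher numbers stand for lower toxicity in this test and lower numbers for higher toxicity in this test), gives > 1000000 nM, which is a limit of the assay.
Compound 2 `O=C(C[C@@H]1COCCO1)C[C@@H]1COCCO1` in this assay gives > 1000000 nM, again a limit.
Compound 3 `C(C[C@@H]1COCCO1)C[C@H]1COCCO1` in this assay gives > 1000000 nM, also a limit.

Compound 3 therefore stands where every measured compound stands: at the limit of this assay, with no number beneath it. For the measured compounds named here, the one measured step that bears on the question, from compound 1 to compound 3, reads a step that the two limits leave unreadable from compound 1 to compound 3; the two limits leave its size unreadable, as the limit of > 1000000 nM in this assay, at which 3 of the 3 values shown sit, shows. Compound 4 `C(C[C@H]1COCCO1)C[C@H]1COCCO1` differs from compound 3 in the same manner: the two compounds have the same atoms and bonds and differ only in configuration as drawn: 1 of 2 stereo elements differ; a stereocentre at a saturated ring carbon is drawn R in compound 3 and S in compound 4. In that it mirrors the pair described by the fact that compounds 1 and 3 differ only in the configuration as drawn. With both measured values sitting at the limit, the account expects no step beyond the scatter from compound 3 to compound 4, so the estimated step is a step that the limit leaves unreadable from compound 3 to compound 4. For compound 4 the expected value in this assay is 2000000 nM, estimated to fall between 1000000 nM and 10000000 nM, most likely reported once more as a limit.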

Compound 4, half-maximal cytotoxic concentration: > 1000000 nM
Compound 4 gave a limit, no number; the forecaster's own chance of this, stated with the estimate: 90%; the middle value does not contradict the limit.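

Compound 4, like compound 1 and compound 3, sits at the limit of this assay, so no step among these three compounds can be read. The compounds shown leave open what concentration would be cytotoxic for any of them, and whether inverting a stereocentre shifts it.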